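The source may hold more compounds than are shown below. What is called first, only, known or untested is meant among the compounds shown, and "the series" means these compounds.

Of the compounds shown here, three that share one core have been tested in a functional assay on PC-3 cells (Homo sapiens) for cytotoxicity; on this read-out lower numbers stand for an effect already at smaller amounts and higher numbers for an effect only at larger amounts of compound. There, compound 1 `COC1=C(C)C(=O)/C(=C(O)/C=C/c2cccc(OC)c2)C(=O)C1(C)C` gives 14.3 ug/mL, compound 2 `COC1=C(C)C(=O)/C(=C(O)/C=C/c2ccc(C)cc2)C(=O)C1(C)C` gives 8.2 ug/mL and compound 3 `COC1=C(C)C(=O)/C(=C(O)/C=C/c2cccc3ccccc23)C(=O)C1(C)C` gives 9 ug/mL. Among the compounds with values here, compound 2 thus stands among close neighbours, with nothing measured so far setting it apart from the other two beyond the usual scatter.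

Compound 4 `COC1=C(C)C(=O)/C(=C(O)/C=C/c2ccco2)C(=O)C1(C)C` keeps the core of compound 2 and alters one group, with furan-2-yl in place of 4-methylphenyl on a double-bonded chain carbon bound to a double-bonded chain carbon. Within the data shown here, the one measured step at this place is a 1.7-fold lower number from compound 1 to compound 2 (0.24 log units; within the scatter), an exchange of one substituted phenyl group for another, and it stays within the scatter. Compound 3, at 9 ug/mL, also carries a different group at this place. Among the measured compounds shown here, no tested compound has a five-membered aromatic ring, so this guide is only indirect.

The expected step is a 1.3-fold higher number from compound 2 to compound 4 (0.13 log units; within the scatter), which would be nothing beyond the scatter. For compound 4 the estimated value is 11 ug/mL, with an expected range from 5.5 ug/mL to 22 ug/mL.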

Compound 4, concentration for half-maximal effect: 20.6 ug/mL
Compound 4: the middle estimate sits 1.9-fold (0.27 log units) below what was measured, and the stated range covers the measured number.
By their numbers in this assay, from the lowest: compounds 2, 3, 1 and 4 (each within the scatter of the next, the first and the last beyond it).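

Within the data shown here, this position can respond to a change of ring: in this assay, furan-2-yl in place of 4-methylphenyl gives a 2.5-fold higher number from compound 2 to compound 4 (0.40 log units; beyond the scatter) and is the first single exchange here to pass the scatter, though only modestly. The same ring in place of 3-methoxyphenyl gives a 1.4-fold higher number from compound 1 to compound 4 (0.16 log units; within the scatter) and so cannot be told apart from that group, which means that the size of the step depends on the group being replaced. No measurement at hand explains the difference between these two steps.

The change from 4-methylphenyl to furan-2-yl alters both the ring size and the ring atoms, so the data cannot show which of these goes with the higher number. A plain phenyl group or a thiophene ring, with sulfur in place of the furan oxygen, would help separate the two.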